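Swapping the aminopropyl chain for a methyl ester

A few compounds are considered here, and "the series" means these few. Any claim that something is new, unique, unknown or untested is made for them only; others in the source may bear on it.

Measured compounds so far:
compound 1 `NCCCNc1c(C(=O)NCc2ccc(F)cc2)nc(Br)c2cccnc12` gives 6000 nM
compound 2 `N[C@H]1CC[C@H](Nc2c(C(=O)NCc3ccccn3)nc(Br)c3cccnc23)CC1` gives 15000 nM
compound 3 `N[C@H]1CC[C@H](Nc2c(C(=O)NC3CCCCC3)nc(Br)c3cccnc23)CC1` gives 5200 nM

All three share one core and were tested in a functional assay on MCF7 cells (Homo sapiens) for cytotoxicity, read by MTT assay, with a stated time of 72 h; on this read-out higher numbers stand for weaker inhibition and lower numbers for stronger inhibition. Among them compound 1 stands second highest; its number sits within the scatter of compound 3, so the two cannot be told apart, while compound 2 lies beyond the scatter above it. Among the measured compounds shown here, the only step between two compounds that differ in one place is a 2.9-fold lower number from compound 2 to compound 3 (0.46 log units; beyond the scatter), a modest change that concerns the group on the amide-type nitrogen, not the chain on the aromatic nitrogen.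

Compound 4 `COC(=O)CNc1c(C(=O)NCc2ccc(F)cc2)nc(Br)c2cccnc12` is the not yet measured partner of compound 1. The change is methoxycarbonyl in place of 2-aminoethyl on a saturated chain carbon bound to a nitrogen on an aromatic ring. The 3-aminopropyl chain thus becomes a (methoxycarbonyl)methyl group on the same nitrogen on the aromatic ring, while the rest of compound 1 is untouched.

For the measured compounds named here, no measured step touches this position, so nothing among the known numbers points in either direction. The estimate for compound 4 therefore stays close to compound 1, with a step of a 1.3-fold higher number from compound 1 to compound 4 (0.12 log units; within the scatter) expected, and a wide range. Compound 4 is expected to give 8000 nM, between 2500 nM and 25000 nM.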

Compound 4, half-maximal inhibitory concentration: > 10000 nM
Compound 4: no number, only a limit; the forecaster's own chance of this, stated with the estimate: 10%; middle value at least 1.2-fold (0.09 log units) away from the limit.
By their numbers in this assay, from the lowest: compounds 3 and 1 (each within the scatter of the next); then compound 2.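

Among the compounds shown here, this is the first measured change at this position, where the 3-aminopropyl chain of compound 1 gives way to a (methoxycarbonyl)methyl group on the same nitrogen, and the earlier step concerned only the group on the amide-type nitrogen. The result for compound 4 in this assay is a limit of the assay and not a number: the limit of > 10000 nM in this assay, at which 1 of the 4 values shown sits. The change therefore gives an at least 1.6-fold higher number from compound 1 to compound 4 (0.22 log units; that floor lies within the scatter), which shows no sign that the methyl ester brings stronger inhibition than the aminopropyl chain, but does not establish a real loss either, as the floor of the step does not clear the scatter.

On these data alone, how far compound 4 actually lies from compound 1 stays unknown, and a single swap that removes the amine and brings in the ester cannot show which of the two matters for the outcome. Also open, as far as these compounds go, is how this position would respond to a carboxylic acid in place of the methyl ester, to a simple alkyl chain with no amine, or to a longer amine chain on the same nitrogen.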